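One Change at the Ether Arm: Compound 2 to Compound 4

The compounds below may be only part of what the source reports. "The series", "measured", "known", "first", "only" and "open" are said of these compounds alone.

Compound 1, `O=S1(=O)C=C(OCc2ccccc2)C(Cc2ccccc2)(Cc2ccccc2)O1`: 200000 nM
Compound 2, `CCC1(Cc2ccccc2)OS(=O)(=O)C=C1OCc1ccc(OC)cc1`: > 200000 nM
Compound 3, `CC(C)C1(Cc2ccccc2)OS(=O)(=O)C=C1OCc1ccccc1`: 200000 nM

Of the compounds shown here, three have been tested in an ADME assay on HEL cells (Homo sapiens) for cytotoxicity, with a stated time of 3 days; on this read-out lower numbers stand for higher toxicity in this test and higher numbers for lower toxicity in this test. Compound 1 gives 200000 nM and compound 3 gives 200000 nM; the step of no change at the digits printed from compound 1 to compound 3 (within the scatter) shows that exchanging one group on the saturated ring carbon left the read-out where it was. The entry for compound 2 is not a number but a limit of the assay: the limit of > 200000 nM in this assay, at which 1 of the 3 values shown sits. Compound 2 therefore stands at the edge of what this test can report, in the region of low toxicity, alongside compound 1 and compound 3.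

Compound 4, `CCC1(Cc2ccccc2)OS(=O)(=O)C=C1OCCc1ccccc1`, differs from compound 2 in one place: benzyl in place of 4-methoxyphenyl on a saturated chain carbon bound to an oxygen on an unsaturated carbon. Going by the values given here, no measured step touches this position, and the only step available, from compound 1 to compound 3, concerns a different part of the shared core and was no change at the digits printed from compound 1 to compound 3 (within the scatter). On that basis no step beyond the scatter is expected, and the estimated step of a number no higher from compound 2 to compound 4 (the limit leaves the size open) is set at none. Compound 4 is expected to give about 200000 nM in this assay, with a likely range from 100000 nM to 400000 nM, and a good chance that again only a limit is reported.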

Compound 4, half-maximal cytotoxic concentration: 48000 nM
Estimate against measurement, compound 4: 4.2-fold (0.62 log units) above; the whole stated range lies above it.
By their numbers in this assay, from the lowest: compound 4; then compounds 1 and 3 (each within the scatter of the next).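

The ether arm is a place where this assay responds to a single change: benzyl in place of 4-methoxyphenyl gives an at least 4.1-fold lower number from compound 2 to compound 4 (0.61 log units; beyond the scatter), and the number moves towards higher toxicity in this test. Going by these compounds alone, the only earlier step, no change at the digits printed from compound 1 to compound 3 (within the scatter), concerned a group on a saturated ring carbon, so the compounds before this one showed no sensitivity at any position. The step has a floor but no known upper size, because the entry for compound 2 is a limit and not a number: the limit of > 200000 nM in this assay, at which 1 of the 4 values shown sits.

The pair alone cannot separate the parts of this change, since the group that leaves carries one hydrogen-bond acceptor and the group that enters carries none, and the two also differ in their heavy atoms, so the read-out does not say which difference matters. From the compounds shown here alone, what an amine, a carboxylic acid or a longer chain would do in this place remains open, as does whether the same exchange would give a comparable step with the isopropyl or the two benzyl groups of compound 3 and compound 1 on the saturated ring carbon.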